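A few compounds are considered here, and "the series" means these few. Any claim that something is new, unique, unknown or untested is made for them only; others in the source may bear on it.

Measured compounds in a functional assay on HOP-62 cells (Homo sapiens) for inhibition, read by sulforhodamine B assay, with a stated time of 48 h; a higher number here means a weaker inhibitor of growth, a lower number a stronger inhibitor of growth:
compound 1 `N=C(N)c1ccc(-c2ccc(-c3cc(Cl)cc(Cl)c3)s2)cc1` gives 1690 nM
compound 2 `N=C(N)c1ccc(-c2ccc(-c3ccc(Cl)cc3)s2)cc1F` gives 1480 nM
compound 3 `COc1cc(OC)cc(-c2ccc(-c3ccc(C(=N)N)c(F)c3)s2)c1` gives 1610 nM

All three share one core and differ only in the groups carried on the outer benzene ring. The numbers in this assay sit close together: compound 2 gives 1480 nM, and both compound 3 and compound 1 lie within the usual scatter of that number, so none of the three can be set apart from the others on these data.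

Compound 4 `COc1ccc(-c2ccc(-c3ccc(C(=N)N)c(F)c3)s2)cc1` has not yet been measured in this assay. It differs from compound 2 in one place: methoxy in place of chloro on an aromatic carbon. Among the measured compounds shown here, no step between two measured compounds reproduces this change, so no measured step can guide the expectation directly. Compound 3, which carries two methoxy groups on that ring, gives 1610 nM, a number within the scatter of compound 2. On that basis the step from chloro to methoxy is expected to stay within the scatter, with no direction favoured, an expected step of a 1.1-fold higher number from compound 2 to compound 4 (0.06 log units; within the scatter). Compound 4 is therefore estimated at 1700 nM, with a range from 800 nM to 3600 nM.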

Compound 4, concentration for 50% growth inhibition: 10400 nM
Compound 4: middle estimate off by 6.1-fold (0.79 log units), on the low side, and the stated range ends below it.
By their numbers in this assay, from the lowest: compounds 2, 3 and 1 (each within the scatter of the next); then compound 4.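

In this assay, methoxy in place of chloro on the aromatic carbon para to a large group is a step beyond the scatter (a 7.0-fold higher number from compound 2 to compound 4 (0.85 log units; beyond the scatter)), so what this place carries can matter to the number. The three earlier compounds could not show this: their numbers lie within the scatter of one another, and no two of them differ in one place only. Nothing at hand bears on why the number rises with this change.

The compounds shown leave open whether the rise follows from the loss of chloro or from the entry of methoxy. A fluoro, a methyl, a hydroxyl or an amine at the same place would help to separate those two readings.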